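The source may hold more compounds than are shown below. What is called first, only, known or untested is meant among the compounds shown, and "the series" means these compounds.

In a functional assay on IMR-32 cells (Homo sapiens) for inhibition, with a stated time of 48 h, tested at 50 uM (a lower number here means less inhibition of growth, a higher number more inhibition of growth at the concentration tested), compound 1 `C=C[C@@](C)(/C=C/c1ccc(OC(C)=O)cc1)CCC=C(C)C` gives 71% and compound 2 `CC[C@](C)(CCCC(C)C)CCc1ccc(O)c(I)c1` gives 21%. Compound 3 `C=C[C@@](C)(/C=C/c1ccc(O)cc1)CC/C=C(/C)C=O` gives 53%, the second highest of the three values. It stands below compound 1 and above compound 2, and both gaps lie beyond the scatter. The next structure is compound 4 `C=C[C@@](C)(/C=C/c1ccc(O)cc1)CCC1OC1(C)C`, which keeps the rest of compound 3 and alters the end of the chain: 3,3-dimethyloxiran-2-yl in place of 2-formylprop-1-en-1-yl on a saturated chain carbon, three bonds along the chain from two double-bonded chain carbons. Here 3,3-dimethyloxiran-2-yl takes the place of 2-formylprop-1-en-1-yl on a saturated chain carbon. For the measured compounds named here, no two measured compounds differ in one place, so the series offers no direct precedent for this change. In this assay a small downward step is expected, with none beyond the scatter, and the wide range reflects the missing precedent. The estimated change is a number 5 percentage points lower from compound 3 to compound 4 (within the scatter). For compound 4 the expected value is 48%, within an estimated range of 32% to 64%.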

Compound 4, percent growth inhibition at one concentration: 59%
For compound 4 the middle estimate is 11 percentage points below the measured one; the measured number falls inside the stated range.
By their numbers in this assay, from the lowest: compound 2; then compounds 3 and 4 (each within the scatter of the next); then compound 1.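

In this assay, for the compounds shown here, the one step read at this position is a number 6 percentage points higher from compound 3 to compound 4 (within the scatter) on replacing 2-formylprop-1-en-1-yl with 3,3-dimethyloxiran-2-yl, so the two end groups cannot be told apart in this read-out. At this saturated chain carbon, an open end group with two double bonds and an end group with a three-membered non-aromatic ring therefore read alike, at the same count of heavy atoms and hydrogen-bond acceptors. No measurement on these compounds accounts for this likeness.

Going by these compounds, how a carboxylic acid or an amine at this chain end would read remains open, as does the effect of a longer chain. The single-concentration read-out also leaves open whether compound 3 and compound 4 would still read alike across a full concentration range.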